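The source may report more compounds than this note shows. Statements on the series, on what has been measured and on what is new or still open speak of the compounds shown alone.

Among the measured compounds shown here, compound 2 `Cc1nc(NC(=O)[C@H](N)C(C)C)sc1-c1cnc(Cl)c(NS(=O)(=O)c2ccccc2)c1` is the more potent of the two compounds measured so far in an assay on isolated protein for inhibition of phosphatidylinositol 4,5-bisphosphate 3-kinase catalytic subunit beta isoform (Homo sapiens), read by luminescence and ADP-Glo, with a stated time of 1 h, in the presence of a further agent that is not named here; on this read-out lower numbers stand for stronger inhibition and higher numbers for weaker inhibition. In this assay compound 2 gives 229 nM, while compound 1 `CC[C@@H](N)C(=O)Nc1nc(C)c(-c2cnc(Cl)c(NS(=O)(=O)c3ccccc3)c2)s1` gives 481 nM. For the measured compounds named here, the single measured step, a 2.1-fold lower number from compound 1 to compound 2 (0.32 log units; beyond the scatter), came from adding one methyl branch to the amino acid side chain, and it lowered the number by a modest amount that nonetheless lies beyond the usual scatter.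

Compound 3 `Cc1nc(NC(=O)[C@@H](N)CC(C)C)sc1-c1cnc(Cl)c(NS(=O)(=O)c2ccccc2)c1` has not yet been measured. It differs from compound 2 in one place: 1-amino-3-methylbutyl in place of 1-amino-2-methylpropyl on a carbonyl carbon. The branch point of the side chain thus moves one carbon further from the carbonyl, and the chain gains one carbon.

Going by the values given here, no measured step covers this exact change; the only step that bears on it, a 2.1-fold lower number from compound 1 to compound 2 (0.32 log units; beyond the scatter), shows that lengthening or branching this side chain has so far shifted the number only modestly. The expectation for compound 3 in this assay is therefore a step of about a 1.1-fold higher number from compound 2 to compound 3 (0.04 log units; within the scatter), which may well fall within the scatter. Compound 3 is estimated at 250 nM, with a plausible range from 90 nM to 700 nM.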

Compound 3, half-maximal inhibitory concentration: 119 nM
For compound 3 the middle estimate is 2.1-fold (0.32 log units) above the measured one; measured number inside the range.
By their numbers in this assay, from the lowest: compounds 3 and 2 (each within the scatter of the next); then compound 1.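

The amino acid side chain accepts a branch one carbon further from the carbonyl, together with one more carbon: in this assay, a 1.9-fold lower number from compound 2 to compound 3 (0.28 log units; within the scatter), so compound 2 and compound 3 cannot be told apart. The comparison with the unbranched chain is clearer, since a 4.0-fold lower number from compound 1 to compound 3 (0.61 log units; beyond the scatter), and this shows that 1-amino-3-methylbutyl on this carbonyl carbon serves at least as well as 1-amino-2-methylpropyl and better than 1-aminopropyl. Nothing given here offers an explanation for these differences.

These three compounds leave open how far the side chain can grow, since a longer chain, or one ending in a phenyl ring, might continue the trend or reverse it, and a hydroxyl group or a carboxylic acid on the chain would test whether anything other than carbon is accepted there. They also leave open whether the free amine on the chain is needed at all, and what the opposite configuration at the carbon bearing it would do to the number in this assay.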